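A Sulfonyl Ring Swap in a Shared Core

A few compounds are considered here, and "the series" means these few. Any claim that something is new, unique, unknown or untested is made for them only; others in the source may bear on it.

Of the compounds shown here, three built on one shared core have been measured. Compound 1 `Cc1ncc(S(=O)(=O)NC(=O)NC/C=C2\CCCc3cnn(Cc4ccc(Cl)cc4Cl)c32)s1` gives 7 nM in an assay on isolated protein for displacement of a labelled ligand from prostaglandin E2 receptor EP3 subtype (Homo sapiens), read by scintillation counting, with a stated time of 2 h; a lower number here means a stronger inhibitor, a higher number a weaker inhibitor. Compound 2 `O=C(NC/C(F)=C1\CCCc2cnn(C3CCN(c4ccc(F)cc4)CC3)c21)NS(=O)(=O)c1cc(Cl)c(Cl)s1` gives 13 nM in this assay, and compound 3 `O=C(NS(=O)(=O)c1cc(Cl)c(Cl)s1)OC/C=C1\CCCc2cnn(Cc3ccc(Cl)cc3Cl)c21` gives 1 nM. Compound 1 thus holds the second-highest of the three numbers; it and compound 2 lie within the usual scatter of each other, whereas compound 3 gives a lower number by a margin beyond that scatter. Compound 4 `Cn1cc(S(=O)(=O)NC(=O)NC/C=C2\CCCc3cnn(Cc4ccc(Cl)cc4Cl)c32)cn1` has not yet been measured. It differs from compound 1 in a single place: 1-methyl-1H-pyrazol-4-yl in place of 2-methyl-1,3-thiazol-5-yl on a sulfonyl sulfur. Going by the values given here, no measured pair shows this exact change, so only a small step, a 1.7-fold higher number from compound 1 to compound 4 (0.23 log units; within the scatter), is expected, not beyond the scatter. Compound 4 is expected to give about 12 nM, within a range from 4 nM to 40 nM.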

Compound 4, inhibition constant: 9 nM
Compound 4: middle estimate off by 1.3-fold (0.12 log units), on the high side; measured number inside the range.
By their numbers in this assay, from the lowest: compound 3; then compounds 1, 4 and 2 (each within the scatter of the next).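

Going by these compounds alone, the swap of 2-methyl-1,3-thiazol-5-yl for 1-methyl-1H-pyrazol-4-yl on the sulfonyl sulfur is the first single-place change available here, and in this assay it reads a 1.3-fold higher number from compound 1 to compound 4 (0.11 log units; within the scatter). At this position, then, these two five-membered aromatic rings cannot be told apart. No measurement shown offers an explanation for this result.

Still open, on these data alone, is whether a plain phenyl ring on the sulfonyl sulfur, or a ring carrying an amine or a carboxylic acid, would fare the same. Also open, as far as these compounds go, is whether this swap would read alike in compound 2 or compound 3.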